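Benzyloxy for chloro on the nitrobenzyl ring

This account rests on a few compounds, and the source may have more. Where it says the series, first, only, none or still open, it means among the compounds named here.

Compound 1 `O=[N+]([O-])c1ccccc1CNc1cc(C(F)(F)F)cc2[nH]ncc12` gives 14000 nM in an assay for inhibition of Indoleamine 2,3-dioxygenase 1 (Homo sapiens), with stated times of 10 min and 60 min; on this read-out lower numbers stand for stronger inhibition and higher numbers for weaker inhibition. Compound 2 `O=[N+]([O-])c1cc(Cl)ccc1CNc1cc(C(F)(F)F)cc2[nH]ncc12` gives 18000 nM in this assay, the higher of the two numbers obtained, though the step of a 1.3-fold higher number from compound 1 to compound 2 (0.11 log units; within the scatter) sits within the scatter. For compound 3 `FC(F)(F)c1cc(NCc2cccc(Br)c2)c2cn[nH]c2c1` only a limit is recorded in this assay, namely > 100000 nM, as noted in the limit of > 100000 nM in this assay, at which 1 of the 3 values shown sits. Compound 4 `O=[N+]([O-])c1cc(OCc2ccccc2)ccc1CNc1cc(C(F)(F)F)cc2[nH]ncc12` is not yet measured; it differs from compound 2 by benzyloxy in place of chloro on an aromatic carbon. Going by the values given here, no measured step exchanges chloro for benzyloxy, and the single step known, a 1.3-fold higher number from compound 1 to compound 2 (0.11 log units; within the scatter), was within the scatter and offers no direction for the present change. Compound 4 is therefore expected at 15000 nM, with a range from 3000 nM to 70000 nM, the step of a 1.2-fold lower number from compound 2 to compound 4 (0.08 log units; within the scatter) being expected to remain within the scatter.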

Compound 4, half-maximal inhibitory concentration: > 100000 nM
Compound 4: a limit, no number; the forecaster's own chance of this, stated with the estimate: 20%; middle value at least 6.6-fold (0.82 log units) away from the limit.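

In this assay the ring carbon meta to the nitro group does not accept every group: benzyloxy in place of chloro gives an at least 5.5-fold higher number from compound 2 to compound 4 (0.74 log units; beyond the scatter) and is thus a change at this position that lies beyond the scatter. Benzyloxy in place of hydrogen agrees, with an at least 7.1-fold higher number from compound 1 to compound 4 (0.85 log units; beyond the scatter) at the same position. Compound 4 has only a limit, not a number: the limit of > 100000 nM in this assay, at which 2 of the 4 values shown sit.

Going by these compounds, the true size of the loss stays open. So does whether a methoxy group, an amine or a carboxylic acid at this position stays near compound 1 or falls away as benzyloxy does.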